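A few compounds are considered here, and "the series" means these few. Any claim that something is new, unique, unknown or untested is made for them only; others in the source may bear on it.

Compound 2, `N#CC1=C(N)Oc2c(N)cc3nc4ccccc4nc3c2C12C(=O)N(Cc1cnnn1-c1ccccc1Br)c1ccccc12`, carries a 2-bromophenyl on an aromatic nitrogen of its five-membered ring with three nitrogens. In an ADME assay on HUVEC cells (Homo sapiens) for antiproliferative activity, read by MTT assay, with a stated time of 48 h (a higher number here means a weaker inhibitor, a lower number a stronger inhibitor), compound 2 gives 34200 nM. That is the only number shown for this series; the other result is a limit of the assay. Compound 1, `Cc1ccc(C)c(-n2nncc2CN2C(=O)C3(C(C#N)=C(N)Oc4c3c3nc5ccccc5nc3c3ccccc43)c3ccccc32)c1`, sits at the limit of > 50000 nM in this assay, at which 1 of the 2 values shown sits. For compound 1 this assay reports only the limit > 50000 nM, not a number. For the measured compounds named here, compound 1 and compound 2 differ in more than one place, so no single step between measured compounds can be drawn, and the two results stand simply as what each shows.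

Compound 3, `N#CC1=C(N)Oc2c(N)cc3nc4ccccc4nc3c2C12C(=O)N(Cc1cnnn1-c1ccc([N+](=O)[O-])cc1[N+](=O)[O-])c1ccccc12`, is the compound still to be measured. It differs from compound 2 in one place: 2,4-dinitrophenyl in place of 2-bromophenyl on an aromatic nitrogen. Going by the values given here, with no comparable step measured, the step in this assay is expected to be small, in no firm direction, and probably not beyond the usual scatter. Compound 3 is therefore expected to give about 32000 nM, most likely between 10000 nM and 100000 nM. This estimate implies an expected step of a 1.1-fold lower number from compound 2 to compound 3 (0.03 log units; within the scatter).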

Compound 3, half-maximal inhibitory concentration: > 50000 nM
Compound 3 gave a limit, no number (the forecaster's own chance of this, stated with the estimate: 35%); middle value at least 1.5-fold (0.19 log units) away from the limit.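

For the compounds shown here, this is the only single change read on the aromatic nitrogen of the five-membered ring, and in this assay it gives an at least 1.4-fold higher number from compound 2 to compound 3 (0.16 log units; that floor lies within the scatter). Compound 3 reports only a limit of the assay, not a number: the limit of > 50000 nM in this assay, at which 2 of the 3 values shown sit. Exchanging 2-bromophenyl for 2,4-dinitrophenyl, which brings hydrogen-bond acceptors to this position, therefore gave no lower number, although the printed floor of the step does not by itself establish a real difference between the two compounds.

The compounds shown leave open how far the step reaches beyond its floor, and whether it goes with the loss of the bromine or with the arrival of the two nitro groups, as both are exchanged together. Also open, as far as these compounds go, is how this assay would read for a phenyl ring at this position carrying a single nitro group, an amine or a carboxylic acid, or for a short alkyl chain on that nitrogen in place of the aromatic ring.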